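Methylamino in place of hydroxy: compound 3 to compound 4

This account rests on a few compounds, and the source may have more. Where it says the series, first, only, none or still open, it means among the compounds named here.

In a functional assay on HCT-8 cells (Homo sapiens) for antiproliferative activity, read by MTT assay, with a stated time of 48 h (on this read-out higher numbers stand for weaker inhibition and lower numbers for stronger inhibition), compound 3 (`COc1ccc(C(=O)c2cc(OC)c(OC)c(OC)c2)c(NC(=O)CO)c1`) gives 120 nM. Compound 1 (`COc1ccc(C(=O)c2ccc(OC)c3c2OC(C)(C)C=C3)c(NC(=O)CO)c1`), which carries the same hydroxy on its chain but has a different core, gives 230 nM, within the usual scatter of compound 3. Compound 2 (`COc1ccc(C(=O)c2ccc(OC)c3c2C=CC(C)(C)O3)c(NC(=O)CN(C)C)c1`) gives 5660 nM, a number higher than that of compound 3 and beyond the scatter. Compound 3 therefore sits with compound 1 at the stronger end of this small set.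

Compound 4 (`CNCC(=O)Nc1cc(OC)ccc1C(=O)c1cc(OC)c(OC)c(OC)c1`) keeps the core of compound 3 and has methylamino in place of hydroxy on a saturated chain carbon bound to a carbonyl carbon. Going by the values given here, no measured pair isolates this change, and compounds 1 and 2 differ in more than one place, so the evidence is indirect. Among the compounds with values here, the only guide is compound 2 at 5660 nM, the sole measured compound with a nitrogen on that chain carbon. On that basis, a step toward weaker inhibition, beyond the scatter, is expected in this assay. The expected size is a 10-fold higher number from compound 3 to compound 4 (1.00 log units; beyond the scatter). For compound 4 the estimated value is 1200 nM, with an expected range from 250 nM to 6000 nM.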

Compound 4, half-maximal inhibitory concentration: 780 nM
For compound 4 the middle estimate is 1.5-fold (0.19 log units) above the measured one, within the range that was stated.
By their numbers in this assay, from the lowest: compounds 3 and 1 (each within the scatter of the next); then compound 4; then compound 2.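

Going by these compounds alone, compound 3 and compound 4 are the first pair to differ in one place, so the effect of this change on a saturated chain carbon bound to a carbonyl carbon can now be read directly: in this assay, methylamino in place of hydroxy gives a 6.5-fold higher number from compound 3 to compound 4 (0.81 log units; beyond the scatter), with the core unchanged. This position is therefore sensitive to the change, even though the two groups have the same hydrogen-bond donor and acceptor counts, neither carries a net charge, and the swap adds only a single heavy atom. The measurements shown offer no basis for explaining the step.

The compounds shown leave open whether a primary amine or a methoxy group on the same chain carbon would give a number closer to that of compound 3 or to that of compound 4, and whether a longer chain carrying the methylamino group would change the picture. They also leave open whether methylamino in place of hydroxy would give a step of similar size on the core of compound 1.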